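Benzyl substituent change in the amide-thiazole series: compound 3

This account rests on a few compounds, and the source may have more. Where it says the series, first, only, none or still open, it means among the compounds named here.

Compound 2 `COc1cccc(Cc2nc(C)c(-c3ccc(C(N)=O)c(C)c3)s2)c1` carries a 3-methoxyphenyl on the saturated chain carbon bound to the shared core. Among the compounds with values here, in a functional assay on cells for agonist activity at G-protein coupled receptor 52 (Homo sapiens), read by AlphaScreen and cAMP accumulation, with a stated time of 30 min (a higher number here means that more compound is needed for the effect, a lower number that less compound is needed), compound 2 gives 160 nM, the highest of the two numbers measured so far. Within the data shown here, its nearest neighbour is compound 1 `Cc1cc(-c2sc(Cc3cccc(C(F)(F)F)c3)nc2C)ccc1C(N)=O`, which in this assay gives 73 nM; the single step on record, a 2.2-fold higher number from compound 1 to compound 2 (0.34 log units; beyond the scatter), is the only guide available for this part of the molecule.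

Compound 3 `Cc1cc(-c2sc(Cc3ccc(Cl)cc3)nc2C)ccc1C(N)=O` is not yet measured. The change from compound 2 is 4-chlorophenyl in place of 3-methoxyphenyl on a saturated chain carbon bound to an aromatic carbon. Among the measured compounds shown here, no measured step covers this exact exchange: the one step on record replaces trifluoromethyl with methoxy at another place on the ring, and it moved the number upward by a modest amount. The new substituent shares neither group nor position with that step, so only a loose expectation can be drawn from it.

For compound 3 a step of a 1.6-fold lower number from compound 2 to compound 3 (0.20 log units; within the scatter) in this assay is expected, modest and downward, on the grounds that compound 1 with a non-methoxy substituent gave 73 nM. Compound 3 is therefore estimated at 100 nM, within a range of 40 nM to 250 nM.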

Compound 3, half-maximal effective concentration: 210 nM
Compound 3: middle estimate off by 2.1-fold (0.32 log units), on the low side; low and high end bracket the measured number.
By their numbers in this assay, from the lowest: compound 1; then compounds 2 and 3 (each within the scatter of the next).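

In this assay, 4-chlorophenyl in place of 3-methoxyphenyl on a saturated chain carbon bound to an aromatic carbon gives a 1.3-fold higher number from compound 2 to compound 3 (0.12 log units; within the scatter) and so does not separate the two compounds, although the two group names differ in both substituent and ring position. Within the data shown here, compound 1 stands at 73 nM and compound 3 at 210 nM, which shows that removing the methoxy group does not by itself bring the number down to that of compound 1, a reading the single earlier step could not give. No measurement on hand accounts for the close agreement of compound 2 and compound 3.

Because substituent and ring position change together in this pair, the compounds shown cannot say whether either one matters on its own, and 3-chlorophenyl and 4-methoxyphenyl would separate the two. Also open, on these data alone, is how this position responds to an unsubstituted phenyl, to a ring bearing an amine or a carboxylic acid, or to a longer chain between the ring and the shared core.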